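This account rests on a few compounds, and the source may have more. Where it says the series, first, only, none or still open, it means among the compounds named here.

Measured compounds:
- compound 1 `CNC(=O)c1cc(Oc2ccc(NC(=O)c3nccc(-c4ccc(OC)cc4)n3)cc2)ccn1` gives 14200 nM
- compound 2 `CNC(=O)c1cc(Oc2ccc(NC(=O)c3cc(-c4ccc(OC)cc4)ncn3)cc2F)ccn1` gives 56200 nM
- compound 3 `CNC(=O)c1cc(Oc2ccc(NC(=O)c3cc(-c4ccccc4)ncn3)cc2)ccn1` gives 44200 nM

All three numbers come from a functional assay on PC-3 cells (Homo sapiens) for cytotoxicity, read by MTT assay, with a stated time of 72 h; a lower number here means a stronger inhibitor, a higher number a weaker inhibitor. Compound 2 carries the highest of the three numbers. Against compound 3 the gap is within the scatter, so no order between these two can be read; against compound 1 the gap lies beyond the scatter, and compound 2 stands as the weaker inhibitor of that pair. Going by the values given here, no step between measured compounds is given, so no measured step sets a scale for the change under consideration.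

Compound 4 `CNC(=O)c1cc(Oc2ccc(NC(=O)c3cc(-c4ccc(C)cc4)ncn3)cc2F)ccn1` is not yet measured. It differs from compound 2 in one place: methyl in place of methoxy on an aromatic carbon. Among the compounds with values here, the difference is small in count, and nothing among the measured compounds speaks to what this exchange does in this assay. The working expectation is a step of no size beyond the scatter, in neither direction with any confidence.

Compound 4 is therefore estimated at 50000 nM, with a range of 20000 nM to 125000 nM, which corresponds to an expected step of a 1.1-fold lower number from compound 2 to compound 4 (0.05 log units; within the scatter).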

Compound 4, half-maximal inhibitory concentration: 40200 nM
For compound 4 the middle estimate is 1.2-fold (0.09 log units) above the measured one, within the range that was stated.
By their numbers in this assay, from the lowest: compound 1; then compounds 4, 3 and 2 (each within the scatter of the next).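

In this assay, going by these compounds alone, methyl in place of methoxy on the aromatic carbon para to a large group gives a 1.4-fold lower number from compound 2 to compound 4 (0.15 log units; within the scatter) as the first measured single-place step. On this pair, going from 4-methoxyphenyl to 4-methylphenyl removes one oxygen and one hydrogen-bond acceptor without a step beyond the scatter, so compound 2 and compound 4 cannot be ordered and the methoxy oxygen is not shown to matter at this position. No supporting measurement is available to explain this result.

From the compounds shown here alone, what an amine such as dimethylamino or a carboxylic acid would give at this same carbon remains open, as does a longer chain such as butoxy. A single exchange also leaves open whether the same step would hold on the core of compound 1.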